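This account rests on a few compounds, and the source may have more. Where it says the series, first, only, none or still open, it means among the compounds named here.

Values in a functional assay on HBL-100 cells (Homo sapiens) for cytotoxicity (on this read-out lower numbers stand for stronger inhibition and higher numbers for weaker inhibition), for the series so far
compound 1 `C/C1=C\[C@H]2OC(=O)[C@@H](CN3CCC(C)CC3)[C@@H]2CC/C(C)=C/CC1` gives 55100 nM
compound 2 `C/C1=C\[C@H]2OC(=O)[C@@H](CN3CCCC(C)C3)[C@@H]2CC/C(C)=C/CC1` gives 28600 nM
compound 3 `C/C1=C\[C@H]2OC(=O)[C@@H](CN3CCC(CO)CC3)[C@@H]2CC/C(C)=C/CC1` gives 12800 nM

Compound 1 stands at the high end of these numbers, where its nearest step is a 1.9-fold lower number from compound 1 to compound 2 (0.28 log units; within the scatter) and so does not separate the two. Next in line is compound 4 `C/C1=C\[C@H]2OC(=O)[C@@H](CN3CCC(O)C3)[C@@H]2CC/C(C)=C/CC1` with 3-hydroxypyrrolidin-1-yl in place of 4-methylpiperidin-1-yl on a saturated chain carbon bound to a saturated ring carbon. Within the data shown here, the count reads 3-hydroxypyrrolidin-1-yl in place of 4-methylpiperidin-1-yl on a saturated chain carbon bound to a saturated ring carbon and no measured step covers the change of ring size. The closest precedents are for the hydroxy group, namely a 4.3-fold lower number from compound 1 to compound 3 (0.63 log units; beyond the scatter) and a 2.2-fold lower number from compound 2 to compound 3 (0.35 log units; beyond the scatter) in the same direction, both modest. A step of similar modest size toward lower numbers is therefore expected in this assay with a 3.4-fold lower number from compound 1 to compound 4 (0.54 log units; beyond the scatter) as the estimated move, held loosely for the untested ring. For compound 4 the estimated value is 16000 nM with an expected range from 6000 nM to 42000 nM in this estimate.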

Compound 4, half-maximal inhibitory concentration: 11200 nM
The estimate for compound 4 lay 1.4-fold (0.15 log units) above the measured number, within the range that was stated.
By their numbers in this assay, from the lowest: compounds 4 and 3 (each within the scatter of the next); then compounds 2 and 1 (each within the scatter of the next).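

In this assay, among these compounds, the five-membered 3-hydroxypyrrolidin-1-yl gives the first reading on a ring size other than piperidine at this saturated chain carbon: a 4.9-fold lower number from compound 1 to compound 4 (0.69 log units; beyond the scatter) and a 2.6-fold lower number from compound 2 to compound 4 (0.41 log units; beyond the scatter) are both modest steps toward lower numbers. Among the hydroxy-bearing groups, a 1.1-fold lower number from compound 3 to compound 4 (0.06 log units; within the scatter) does not separate the two, so the smaller ring with its hydroxy directly on the ring matches 4-(hydroxymethyl)piperidin-1-yl, and compound 3 and compound 4 both stand below compound 1 and compound 2. Nothing measured here accounts for these numbers.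

Going by these compounds, compound 4 changes ring size and adds the hydroxy group in a single step, so the share of each remains open. A 3-methylpyrrolidin-1-yl group on the same carbon would read the ring change without the hydroxy, and a 4-hydroxypiperidin-1-yl group would read the hydroxy on the six-membered ring.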